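Methyl Next to the Ring Nitrogen: Compound 4

A few compounds are considered here, and "the series" means these few. Any claim that something is new, unique, unknown or untested is made for them only; others in the source may bear on it.

Compound 1 `N/C(=N\NC(=S)N1CCCCCC1)c1ccccn1` gives 90% in a functional assay on A-375 cells (Homo sapiens) for cytotoxicity, read by MTT assay, with a stated time of 72 h, tested at 30 uM (a lower number here means less inhibition of growth, a higher number more inhibition of growth at the concentration tested), the highest of the three numbers shown. Compound 2 `N/C(=N\NC(=S)N1CCOCC1)c1ccccn1` gives 15% in this assay, and compound 3 `Cc1ccnc(/C(N)=N/NC(=S)N2CCCCCC2)c1` gives 76.5%. For the measured compounds named here, the step of a number 13.5 percentage points lower from compound 1 to compound 3 (beyond the scatter) is the only measured change of the kind now in question. Compound 4 `Cc1cccc(/C(N)=N/NC(=S)N2CCCCCC2)n1` differs from compound 1 by methyl in place of hydrogen on an aromatic carbon, the methyl now sitting next to the ring nitrogen. Going by the values given here, since the one step that bears on this, from compound 1 to compound 3, was modest and downward, a similar modest drop in this assay is expected, with room for a smaller or larger step at the new place. Compound 4 is therefore estimated at 78%, between 58% and 92%, which is expected to mean a number 12 percentage points lower from compound 1 to compound 4 (beyond the scatter).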

Compound 4, percent growth inhibition at one concentration: 70.3%
Compound 4: middle estimate off by 7.7 percentage points, on the high side; the measured number falls inside the stated range.
By their numbers in this assay, from the lowest: compound 2; then compounds 4 and 3 (each within the scatter of the next); then compound 1.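

In this assay methyl next to the ring nitrogen also gives a number 19.7 percentage points lower from compound 1 to compound 4 (beyond the scatter) and so the drop seen with compound 3 is not confined to one place on the ring. Compound 4 at 70.3% and compound 3 at 76.5% lie within the scatter of each other, so these two places cannot be told apart in this measurement. Nothing available accounts for the drop at either place.

The compounds shown leave open whether an ethyl chain, a chlorine or an amine at this place would change the number differently from methyl.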